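The source may report more compounds than this note shows. Statements on the series, on what has been measured and on what is new or still open speak of the compounds shown alone.

Measured so far:
- compound 1 `CN1C/C(=C\c2ccncc2)C(=O)/C(=C/c2cc([N+](=O)[O-])ccc2F)C1` gives 5200 nM in a functional assay on HepG2 cells (Homo sapiens) for cytotoxicity, read by MTT assay, with a stated time of 24 h (on this read-out higher numbers stand for weaker inhibition and lower numbers for stronger inhibition), on this series
- compound 2 `O=C1/C(=C/c2cccnc2)CNC/C1=C\c1ccccc1F` gives 21000 nM in this assay on this series

Compound 2 stands highest of the two at 21000 nM and is the weaker inhibitor, with compound 1 lower by more than the scatter.

Compound 3 `O=C1/C(=C/c2cccnc2)CN(S(=O)(=O)c2ccc(F)cc2)C/C1=C\c1ccccc1F` is still unmeasured. Within the data shown here, it carries (4-fluorophenyl)sulfonyl in place of hydrogen on an amine nitrogen in a ring of compound 2 (4-fluorophenyl)sulfonyl in place of hydrogen on an amine nitrogen in a ring as its only change. Among the measured compounds shown here, no measured pair isolates a change of this kind, and compound 1 differs from compound 2 in several places, so it is only a loose guide. A step beyond the scatter towards a lower number in this assay is expected, resting only on compound 1 at 5200 nM as the lower value. The estimated step is a 3.5-fold lower number from compound 2 to compound 3 (0.54 log units; beyond the scatter) in size. Compound 3 is expected at 6000 nM with an estimated range of 1800 nM to 20000 nM for now.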

Compound 3, half-maximal inhibitory concentration: 15600 nM
Compound 3: middle estimate off by 2.6-fold (0.41 log units), on the low side; measured number inside the range.
By their numbers in this assay, from the lowest: compound 1; then compounds 3 and 2 (each within the scatter of the next).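

In this assay, among these compounds, (4-fluorophenyl)sulfonyl in place of hydrogen on an amine nitrogen in a ring gives a 1.3-fold lower number from compound 2 to compound 3 (0.13 log units; within the scatter), the first single-place step at this position, and it lies within the scatter. At this level of comparison, the position takes a group of 10 heavy atoms, including a six-membered aromatic ring and 2 hydrogen-bond acceptors, with no difference beyond the scatter in this read-out. No measurement shown here bears on why this change leaves the two compounds within the scatter.

As far as these compounds go, it remains open whether an acetyl, a benzyl or a carboxylic acid chain on the same nitrogen would also stay within the scatter. Compound 1, at 5200 nM, differs from compound 2 in several places, so no part of its value can be assigned to the group on this nitrogen.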